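A few compounds are considered here, and "the series" means these few. Any claim that something is new, unique, unknown or untested is made for them only; others in the source may bear on it.

Measured compounds:
Compound 1, `CCCC#Cc1cn([C@@H]2O[C@H](CO)[C@@H](O)[C@H](O)[C@H]2O)c(=O)[nH]c1=O` — in a functional assay on L1210 cells (Mus musculus) for cytotoxicity, with a stated time of 48 h (a higher number here means a weaker inhibitor, a lower number a stronger inhibitor), compound 1 gives 115000 nM
Compound 2, `CCCCCC#Cc1cn([C@@H]2O[C@H](CO)[C@@H](O)[C@H](O)[C@H]2O)c(=O)nc1N` — compound 2 gives only a limit of the assay, >= 250000 nM
Compound 3, `O=c1nc(O)c(C#Cc2ccccc2)cn1[C@@H]1O[C@H](CO)[C@@H](O)[C@H](O)[C@H]1O` — compound 3 gives 6200 nM

Among the two compounds that gave a number in this assay, compound 1 stands at the higher end, with compound 3 giving a clearly lower number, a gap that lies beyond the usual scatter. Compound 2 is reported only as a limit, which is where one of the three values sits (the limit of >= 250000 nM in this assay, at which 1 of the 3 values shown sits).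

Compound 4, `O=c1[nH]c(=O)n([C@@H]2O[C@H](CO)[C@@H](O)[C@H](O)[C@H]2O)cc1CCc1ccccc1`, is not yet measured in this assay. It differs from compound 1 in one place: phenethyl in place of pent-1-yn-1-yl on an aromatic carbon. The chain of five carbon atoms with its triple bond is replaced by a phenethyl group carrying a six-membered aromatic ring of carbon only.

Going by the values given here, no measured pair differs in exactly this way, so the size of the step is uncertain. The number for compound 4 is expected to fall below that of compound 1, a step of a 2.9-fold lower number from compound 1 to compound 4 (0.46 log units; beyond the scatter), drawn toward the lower value of compound 3 with its own aromatic ring, 6200 nM. Compound 4 is estimated at 40000 nM, within a range from 8000 nM to 200000 nM.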

Compound 4, half-maximal inhibitory concentration: 300000 nM
Compound 4: the middle estimate sits 7.5-fold (0.88 log units) below what was measured, outside the stated range (above it).
By their numbers in this assay, from the lowest: compound 3; then compound 1; then compound 4.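

Swapping pent-1-yn-1-yl for phenethyl on this aromatic carbon of the shared core gives a 2.6-fold higher number from compound 1 to compound 4 (0.42 log units; beyond the scatter) in this assay, so a larger group carrying an aromatic ring does not lower the number here. An aromatic ring at this position is therefore not enough for a low number: compound 3 also carries one and gives 6200 nM, whereas compound 4 gives 300000 nM. The data shown offer no measured property that accounts for this rise.

Still open, on these data alone, is how a plain pentyl chain, without the triple bond, would compare with pent-1-yn-1-yl at this position. As far as these compounds go, it is also open whether an amine or a carboxylic acid on the aromatic ring of phenethyl would move the number in either direction.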